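Swapping a ring substituent on a shared benzamide-linked core

The source may report more compounds than this note shows. Statements on the series, on what has been measured and on what is new or still open speak of the compounds shown alone.

Measured compounds:
compound 1, `COc1ccc(N2CCN(C(=S)SCc3ccc(C(=O)Nc4ccccc4N)cc3)CC2)cc1`, 25.3%
compound 2, `CN(Cc1ccncc1)C(=S)SCc1ccc(C(=O)Nc2ccccc2N)cc1`, 38.1%

Both compounds were tested in a functional assay on MGC-803 cells (Homo sapiens) for antiproliferative activity, read by CCK-8 assay, with a stated time of 72 h, tested at 2 uM; on this read-out lower numbers stand for a weaker effect and higher numbers for a stronger effect at the one concentration tested. Compound 1 gives 25.3%, the lower of the two numbers recorded; compound 2 gives 38.1%, a gap that lies beyond the usual scatter of this assay. Among the compounds with values here, no pair of measured compounds differing in a single place is available, so the effect of any one change on this read-out is not known from the data.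

Compound 3, `Nc1ccccc1NC(=O)c1ccc(CSC(=S)N2CCN(C3CCCCC3)CC2)cc1`, has not yet been measured. It differs from compound 1 in one place: cyclohexyl in place of 4-methoxyphenyl on an amine nitrogen in a ring. Within the data shown here, with no measured step to guide the direction, the step from compound 1 to compound 3 is expected to be a number 4.7 percentage points higher from compound 1 to compound 3 (within the scatter), that is, no clear change beyond the scatter. Compound 3 is therefore estimated to show 30% in this assay, with a plausible range from 12% to 50%.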

Compound 3, a percentage reported as inhibition, at one concentration (the size of the read-out at that concentration, not a potency): 16.9%
For compound 3 the middle estimate is 13.1 percentage points above the measured one, within the range that was stated.
By their numbers in this assay, from the lowest: compounds 3 and 1 (each within the scatter of the next); then compound 2.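

In this assay, within the data shown here, putting cyclohexyl in place of 4-methoxyphenyl on an amine nitrogen in a ring gives a number 8.4 percentage points lower from compound 1 to compound 3 (within the scatter), the first step that can be read at this position. The read-out therefore does not separate these two groups at the one concentration tested, even though the six-membered ring loses its aromatic character and the hydrogen-bond acceptor of the methoxy group is gone. No available measurement bears on what lies behind this result.

As far as these compounds go, it remains open whether a different kind of group on this nitrogen, such as a small methyl, a benzyl or a chain ending in a carboxylic acid, would move the read-out beyond the scatter. Compound 2 differs from compound 1 and compound 3 in more than one place, so its value cannot be traced to any single change.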